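A smaller pyridine group on the shared core

The compounds below may be only part of what the source reports. "The series", "measured", "known", "first", "only" and "open" are said of these compounds alone.

Measured compounds:
compound 1, `COc1ccc(-c2c(C)nn(-c3nc(-c4ccc(Cl)c(Cl)c4)c(SC(C)C)s3)c2C(=O)O)cc1`, gives 2100 nM in a functional assay on BJAB cells (Homo sapiens) for antiproliferative activity, with a stated time of 4 days; a higher number here means that more compound is needed for the effect, a lower number that less compound is needed
compound 2, `Cc1nn(-c2nc(-c3ccc(Cl)c(Cl)c3)c(SC(C)C)s2)c(C(=O)O)c1Cc1ccccc1[N+](=O)[O-]`, gives 20000 nM in this assay
compound 3, `Cc1cc(-c2c(C)nn(-c3nc(-c4ccc(Cl)c(Cl)c4)c(SC(C)C)s3)c2C(=O)O)cc(C)n1`, gives 580 nM in this assay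

Among these three, compound 3 stands lowest, meaning the least compound is needed: a 3.6-fold lower number from compound 1 to compound 3 (0.56 log units; beyond the scatter) and a 34-fold lower number from compound 2 to compound 3 (1.54 log units; beyond the scatter) both lie beyond the scatter, so this position is clearly sensitive to which group sits there.

Compound 4, `Cc1nn(-c2nc(-c3ccc(Cl)c(Cl)c3)c(SC(C)C)s2)c(C(=O)O)c1-c1cccnc1`, has not yet been measured. It differs from compound 3 in one place: pyridin-3-yl in place of 2,6-dimethylpyridin-4-yl on an aromatic carbon. The change keeps an aromatic ring with one nitrogen but removes two methyl groups and moves the nitrogen within the ring.

Within the data shown here, two measured steps bear on this. The exchange of a 4-methoxyphenyl for the 2,6-dimethylpyridin-4-yl gave a 3.6-fold lower number from compound 1 to compound 3 (0.56 log units; beyond the scatter), a modest gain. The exchange of a 2-nitrobenzyl gave a 34-fold lower number from compound 2 to compound 3 (1.54 log units; beyond the scatter), a large one. From the compounds shown here alone, neither tests a plain pyridine lacking methyl groups, so the pull of the two methyls is unknown. Because a 3.6-fold lower number from compound 1 to compound 3 (0.56 log units; beyond the scatter) shows that a different aromatic group in this place costs only modestly, a modest rise in the number for compound 4 is expected, possibly within the scatter.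

Compound 4 is therefore estimated at 1200 nM, with a range of 400 nM to 3500 nM, an expected step of a 2.1-fold higher number from compound 3 to compound 4 (0.32 log units; beyond the scatter).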

Compound 4, half-maximal effective concentration: 12000 nM
Beside the measured number, compound 4's estimate is 10-fold (1.00 log units) below it; the whole stated range lies below it.
By their numbers in this assay, from the lowest: compound 3; then compound 1; then compounds 4 and 2 (each within the scatter of the next).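

Replacing the 2,6-dimethylpyridin-4-yl with pyridin-3-yl gives a 21-fold higher number from compound 3 to compound 4 (1.32 log units; beyond the scatter) in this assay and is a large step, so keeping an aromatic ring with one nitrogen at this place does not by itself keep the low number of compound 3. The pyridine ring no longer sits on the favourable side of the 4-methoxyphenyl either: the change to pyridin-3-yl gives a 5.7-fold higher number from compound 1 to compound 4 (0.76 log units; beyond the scatter) and shows that, among the three aromatic groups here, pyridine rings occupy both the lowest and the highest places. The comparison with the 2-nitrobenzyl group gives a 1.7-fold lower number from compound 2 to compound 4 (0.22 log units; within the scatter) and leaves those two compounds unseparated in this assay, so a plain pyridine offers no measurable advantage over that group.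

This change removes two methyl groups and moves the ring nitrogen at once, and telling those two effects apart would take a pyridin-4-yl without methyl groups or a pyridin-3-yl carrying them. No measurement among those shown explains the size of this step.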